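This account rests on a few compounds, and the source may have more. Where it says the series, first, only, none or still open, it means among the compounds named here.

Working notes on the series. Three compounds share the fused bicyclic core carrying a benzyl group; they differ in the ring substituents and in where the chloromethyl group sits on the benzyl ring. Compound 1 `ClCc1cccc(Cn2cnc3c(Cl)nc(Cl)nc32)c1` gives 750 nM in a functional assay on RXF 393 cells (Homo sapiens) for cytotoxicity, read by sulforhodamine B assay, with a stated time of 48 h (a lower number here means a stronger inhibitor of growth, a higher number a weaker inhibitor of growth), the lowest of the three numbers. Compound 2 `Nc1nc(Cl)c2ncn(Cc3ccc(CCl)cc3)c2n1` gives 1320 nM in this assay, which lies within the scatter of compound 1, so no order between the two is claimed. Compound 3 `ClCc1ccccc1Cn1cnc2ncnc(Cl)c21` gives 1650 nM in this assay, beyond the scatter from compound 1 and thus the weaker of that pair.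

Compound 4 `ClCc1cccc(Cn2cnc3c(Cl)ncnc32)c1` has not been measured. It differs from compound 1 in one place: hydrogen in place of chloro on an aromatic carbon. Among the measured compounds shown here, no measured pair in this set isolates that change, so the expectation rests on the spread of the three numbers alone. The step from compound 1 to compound 4 in this assay is expected to be small, toward a higher number, and possibly no larger than the scatter, giving a 1.6-fold higher number from compound 1 to compound 4 (0.20 log units; within the scatter). Compound 4 is estimated at 1200 nM, with a range from 500 nM to 3000 nM.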

Compound 4, concentration for 50% growth inhibition: 2290 nM
Compound 4: the middle estimate sits 1.9-fold (0.28 log units) below what was measured; measured number inside the range.
By their numbers in this assay, from the lowest: compounds 1, 2, 3 and 4 (each within the scatter of the next, the first and the last beyond it).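

Among the compounds shown here, this is the first pair that isolates a single change: the chloro group on the aromatic carbon between two ring nitrogen atoms. In this assay, hydrogen in place of that chloro gives a modest step beyond the scatter (a 3.1-fold higher number from compound 1 to compound 4 (0.48 log units; beyond the scatter)), so on the scaffold of compound 1, with its chloromethyl group unchanged, this chloro contributes measurably to growth inhibition. The data at hand offer no explanation for the size or direction of this step.

The compounds shown compare only hydrogen and chloro at this position, so the effect of an amine or a methoxy group there remains open. Also open, as far as these compounds go, is whether the step holds when the chloromethyl group sits elsewhere on the benzyl ring.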